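Replacing the 3-hydroxyphenyl group of compound 1

The source may report more compounds than this note shows. Statements on the series, on what has been measured and on what is new or still open speak of the compounds shown alone.

Compound 1 `COC(=O)N1N=C(c2cccc(O)c2)CC1c1cc(OC)c(OC)c(OC)c1` gives 1970 nM
Compound 2 `CCOC(=O)N1N=C(c2cccc(O)c2)CC1c1cc(OC)c(OC)c(OC)c1` gives 3280 nM

Both values come from a functional assay on HeLa cells (Homo sapiens) for antiproliferative activity, read by MTT assay, with a stated time of 48 h (on this read-out lower numbers stand for stronger inhibition of growth and higher numbers for weaker inhibition of growth), and lie within the scatter of each other, so compound 1 stands level with compound 2. Compound 3 `COC(=O)N1N=C(c2ccc(OC)c(OC)c2)CC1c1cc(OC)c(OC)c(OC)c1` keeps the core of compound 1 but carries 3,4-dimethoxyphenyl in place of 3-hydroxyphenyl on a carbon with a double bond to nitrogen in the structure. Among the measured compounds shown here, the one measured step, a 1.7-fold higher number from compound 1 to compound 2 (0.22 log units; within the scatter), lies at the methoxycarbonyl group and does not touch this place. The expectation therefore rests mainly on the value of compound 1 (1970 nM) and remains uncertain. A modest move toward weaker inhibition of growth is expected, with an estimated size of a 1.8-fold higher number from compound 1 to compound 3 (0.25 log units; within the scatter) as the best guess. In this assay compound 3 is estimated at 3500 nM, with 900 nM to 14000 nM as the expected range.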

Compound 3, concentration for 50% growth inhibition: 3390 nM
Compound 3: middle estimate off by 1.0-fold (0.01 log units), on the high side; measured number inside the range.
By their numbers in this assay, from the lowest: compounds 1, 2 and 3 (each within the scatter of the next).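

Among the compounds shown here, the first step at this position is the exchange of 3-hydroxyphenyl for 3,4-dimethoxyphenyl on the carbon with a double bond to nitrogen, and in this assay it gives a 1.7-fold higher number from compound 1 to compound 3 (0.24 log units; within the scatter) and so stays within the scatter. The hydroxy group of compound 1 is thus not needed to keep a value within the scatter of compound 1, even though the entering group has no hydrogen-bond donor and more heavy atoms. The exchange changes two things on the phenyl ring at once, so this single step cannot separate them, and nothing given here accounts for the result.

For the compounds shown here, it remains open how 3-methoxyphenyl, with only one of these changes, would read in this assay at this position. Also open, as far as these compounds go, is what an amine, a carboxylic acid or a longer chain such as propoxy would do on this phenyl ring.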